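Methylating the Pyrazole Nitrogen in Two Related Cores

The compounds below may be only part of what the source reports. "The series", "measured", "known", "first", "only" and "open" are said of these compounds alone.

Two compounds with a free aromatic nitrogen-hydrogen were measured first: compound 1 `COc1ccc(-c2cc3[nH]nc(N)c3c(=O)[nH]2)cc1` and compound 2 `Cc1cc2[nH]nc(N)c2c(N2CCCCC2)n1`. In an assay on isolated protein for inhibition of RAC-beta serine/threonine-protein kinase (Homo sapiens), read by mobility shift assay, tested at 30 uM (on this read-out higher numbers stand for more inhibition at the one concentration tested (going by the name of the read-out) and lower numbers for less inhibition), compound 1 gives 11%, and compound 2 gives 11%, so the two stand level at the digits reported. How the core of compound 2 differs from the core of compound 1 is not broken down here.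

Compound 3 `COc1ccc(-c2cc3c(c(N)nn3C)c(=O)[nH]2)cc1` carries one change relative to compound 1, (methyl in place of hydrogen on an aromatic nitrogen). In this assay compound 3 gives -8%, and the step of a number 19 percentage points lower from compound 1 to compound 3 (beyond the scatter) is modest but beyond the usual scatter.

Compound 4 `Cc1cc2c(c(N)nn2C)c(N2CCCCC2)n1` is the matching partner of compound 2, with the same change, (methyl in place of hydrogen on an aromatic nitrogen), at the same place. For the measured compounds named here, since the one measured instance of this change gave a number 19 percentage points lower from compound 1 to compound 3 (beyond the scatter), the author expects a step of about the same size, a number 19 percentage points lower from compound 2 to compound 4 (beyond the scatter), in this assay. Compound 4 is therefore estimated at -8%, with a likely range from -25% to 10%, resting on a single precedent only.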

Compound 4, a percentage reported as inhibition, at one concentration (the size of the read-out at that concentration, not a potency): 0%
For compound 4 the middle estimate is 8 percentage points below the measured one; measured number inside the range.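

On the core of compound 2, methyl in place of hydrogen on an aromatic nitrogen again goes with a lower number in this assay, a number 11 percentage points lower from compound 2 to compound 4 (beyond the scatter). For the compounds shown here, the change therefore carries from one core to the other in the same direction, and the two steps cannot be told apart in size: the same change on two cores in this assay, a number 19 percentage points lower (beyond the scatter) from compound 1 to compound 3 and a number 11 percentage points lower (beyond the scatter) from compound 2 to compound 4, 8 percentage points apart, within the scatter of two such steps This rests on only two matched pairs, each tested at a single concentration, so it sets no general rule for other cores and gives no reason why the number falls.

The compounds shown leave open whether a longer chain, such as ethyl or propyl, on the same aromatic nitrogen would follow the methyl step. They also leave open what an amide or a carboxylic acid would do in place of the amino group on either core.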